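Shifting One Methyl on the Phenyl Ring

The source may hold more compounds than are shown below. What is called first, only, known or untested is meant among the compounds shown, and "the series" means these compounds.

Two compounds of this series carry numbers for how well they dissolve. Among the compounds with values here, compound 1 `Cc1ccc(C)c(-c2nc(CN3CCC(C(=O)NCCCN4C[C@H](C)C[C@H](C)C4)CC3)c(C)o2)c1` was tested in a physicochemical assay for solubility, in phosphate buffer, measured as kinetic solubility, at pH 7.4; on this read-out lower numbers stand for lower solubility and higher numbers for higher solubility; in this assay compound 1 gives 56.1 ug/mL, the only plain number in the set. Compound 2 `Cc1ccccc1-c1nc(CN2CCC(C(=O)N3CCN(CCN(C)C)CC3)CC2)c(C)o1` was tested in the same assay, and there compound 2 gives > 67 ug/mL, which is a limit of the assay rather than a measured number. Put another way, (the limit of > 67 ug/mL in this assay, at which 1 of the 2 values shown sits). Within the data shown here, no two measured compounds differ in only one place, so no measured step is available to calibrate what a single change does.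

Compound 3 `Cc1cccc(C)c1-c1nc(CN2CCC(C(=O)NCCCN3C[C@H](C)C[C@H](C)C3)CC2)c(C)o1` has not been measured yet. It differs from compound 1 in one place: 2,6-dimethylphenyl in place of 2,5-dimethylphenyl on an aromatic carbon. Both compounds contain the same atoms, only joined differently. Among the measured compounds shown here, with no measured step to lean on, the expectation for compound 3 is a change in the same assay that stays within the usual scatter, as expressed by the estimated step of a 1.1-fold lower number from compound 1 to compound 3 (0.05 log units; within the scatter). Compound 3 is therefore expected to show about 50 ug/mL, with a likely range from 25 ug/mL to 90 ug/mL.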

Compound 3, solubility: 55.9 ug/mL
Compound 3: middle estimate off by 1.1-fold (0.05 log units), on the low side; the measured number falls inside the stated range.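

Until now the series offered no single change to read, since compound 1 and compound 2 differ in more than one place. Compound 3 supplies the first such change: moving one methyl around the phenyl ring, from 2,5-dimethylphenyl to 2,6-dimethylphenyl, gives a 1.0-fold lower number from compound 1 to compound 3 (0.00 log units; within the scatter) in this assay, so at this position the two arrangements of the same atoms cannot be told apart on this read-out. The measurements shown offer no reason for this outcome, and a matching pair of numbers by itself explains nothing.

This one pair speaks only for a shift of a methyl on the phenyl ring, with the side chain of compound 1 in place, and it cannot say whether a different group there, such as methoxy, a chlorine atom or an amine, would give a step beyond the scatter. Also open, on these data alone, is whether the same shift would read alike with the side chain of compound 2, whose value is only a limit.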